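Ether-Linked Variant of a Sulfonamide Series

A few compounds are considered here, and "the series" means these few. Any claim that something is new, unique, unknown or untested is made for them only; others in the source may bear on it.

Compound 1 `Cc1ccc(S(=O)(=O)Nc2ccc(-c3ccsc3)c3cccnc23)cc1`: 4090 nM
Compound 2 `Cc1ccc(S(=O)(=O)Nc2ccc(-c3cc4ccccc4s3)c3cccnc23)cc1`: "not active" (no number reported)
Compound 3 `Cc1ccc(S(=O)(=O)Nc2cc(Oc3cc(F)cc(F)c3)cc3cccnc23)cc1`: 2460 nM

Of the compounds shown here, three built on a shared core have been measured in a functional assay on NCI-H1299 cells (Homo sapiens) for antiproliferative activity, with a stated time of 2 days; a lower number here means a stronger inhibitor, a higher number a weaker inhibitor. Compound 1 gives 4090 nM in this assay. Compound 2 is reported as "not active" (no number reported), with no number given. Compound 3 gives 2460 nM in this assay, and its value and that of compound 1 lie within the usual scatter of each other, so no order can be read between the two.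

Compound 4 `Cc1ccc(S(=O)(=O)Nc2cc(Oc3cccc(C#N)c3)cc3cccnc23)cc1` has not yet been measured. It differs from compound 3 by a single change: 3-cyanophenyl in place of 3,5-difluorophenyl on an oxygen on an aromatic ring. For the measured compounds named here, no pair of measured compounds in this set differs in one place, so there is no measured step from which the size of this change can be read. Nothing in the available numbers points in either direction, and the expectation is therefore a step for compound 4 that stays within the scatter of the measurement. Compound 4 is expected to give about 3000 nM in this assay, within a range from 1000 nM to 9000 nM. The step from compound 3 to compound 4 is estimated as a 1.2-fold higher number from compound 3 to compound 4 (0.09 log units; within the scatter).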

Compound 4, half-maximal inhibitory concentration: "not active" (no number reported)
The entry for compound 4 holds no number; the estimate stays without a comparison.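

In this assay, for the compounds shown here, compound 4 is reported without a number, and no step from compound 3 can be read from it. No available information bears on this result. The compounds shown leave open how far the exchange of 3,5-difluorophenoxy for 3-cyanophenoxy shifts the antiproliferative read-out, and whether any single change on the shared core does.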